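A few compounds are considered here, and "the series" means these few. Any claim that something is new, unique, unknown or untested is made for them only; others in the source may bear on it.

In a functional assay on HepG2 cells (Homo sapiens) for antiproliferative activity, read by CCK-8 assay, with a stated time of 72 h (a higher number here means a weaker inhibitor, a lower number a stronger inhibitor), the hydroxamic acid compound 1 `O=C(NO)c1ccc(COc2ccccc2)cc1` gives 29600 nM. Compound 2 `Nc1ccccc1NC(=O)c1ccc(COc2ccc(Cl)cc2)cc1`, which carries a chloro group, gives > 32000 nM, a limit of the assay and not a number. Compound 3 `Nc1ccccc1NC(=O)c1ccc(COc2ccccc2)cc1` gives 6700 nM, the lowest number among the three and the starting point here.

Compound 4 `Nc1cc(F)ccc1NC(=O)c1ccc(COc2ccccc2)cc1` differs from compound 3 by fluoro in place of hydrogen on an aromatic carbon. This puts fluoro in place of hydrogen on an aromatic carbon, turning 2-aminophenyl into 2-amino-4-fluorophenyl.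

Going by the values given here, no measured step makes this same change. The nearest is an at least 4.7-fold lower number from compound 2 to compound 3 (0.67 log units; beyond the scatter), where a chloro group gives way to hydrogen elsewhere in the molecule. The size of that step for compound 2 rests on (the limit of > 32000 nM in this assay, at which 1 of the 3 values shown sits). The other step, a 4.4-fold lower number from compound 1 to compound 3 (0.65 log units; beyond the scatter), shows that this assay responds to the group on the amide nitrogen, but it replaces hydroxy with the whole 2-aminophenyl group and so says little about a single fluoro. Neither step transfers directly to the new position, and a change of one heavy atom is therefore expected to leave the number close to that of compound 3. The expected result is a 1.0-fold lower number from compound 3 to compound 4 (0.01 log units; within the scatter), with no shift beyond the scatter anticipated. For compound 4 the estimated value is 6500 nM, with an expected range from 2300 nM to 19000 nM.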

Compound 4, half-maximal inhibitory concentration: 7020 nM
Compound 4: the middle estimate sits 1.1-fold (0.03 log units) below what was measured; measured number inside the range.
By their numbers in this assay, from the lowest: compounds 3 and 4 (each within the scatter of the next); then compound 1. At a limit, above all of these: compound 2.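

In this assay, the first change shown on the 2-aminophenyl group itself, with fluoro in place of hydrogen on the aromatic carbon meta to an amino group and para to a large group, gives a 1.0-fold higher number from compound 3 to compound 4 (0.02 log units; within the scatter) and so does not move the number beyond the scatter. Going by these compounds alone, the earlier compounds showed only a change from chloro to hydrogen elsewhere in the molecule and a replacement of hydroxy by the whole 2-aminophenyl group, so this is the first sign that this position accepts a single fluoro in this cell assay. The difference from the hydroxamic acid also remains with the new group, at a 4.2-fold lower number from compound 1 to compound 4 (0.62 log units; beyond the scatter) and beyond the scatter, while nothing in the supporting data bears on why the fluoro leaves the number where it is.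

The compounds shown leave open whether a larger group at the same carbon, such as chloro, methoxy or trifluoromethyl, would behave as fluoro does. They also leave open whether fluoro on another carbon of this ring, or a second amino group in its place, would shift the number beyond the scatter in this assay in either direction.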